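A Methyl Added to the Core of Compound 1

A few compounds are considered here, and "the series" means these few. Any claim that something is new, unique, unknown or untested is made for them only; others in the source may bear on it.

Compound 1 `CC(C)Sc1nc(Cc2c(F)cccc2Cl)cc(=O)[nH]1` carries an isopropyl group on a sulfur. In an ADME assay on MT4 cells (Homo sapiens) for activation, read by MTT assay (a higher number here means that more compound is tolerated, a lower number that less compound is tolerated), compound 1 gives > 80000 nM, which is a limit and not a number. Compound 2 `CCCCSc1nc(Cc2c(F)cccc2Cl)cc(=O)[nH]1`, with butyl on the sulfur, gives > 76000 nM, also a limit. Compound 3 `O=c1cc(Cc2c(F)cccc2Cl)nc(SC2CCCC2)[nH]1`, with cyclopentyl on the sulfur, gives > 74000 nM, again a limit. Compound 1 therefore has no exact value, and neither do the other two.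

Compound 4 `Cc1c(Cc2c(F)cccc2Cl)nc(SC(C)C)[nH]c1=O` keeps the isopropylsulfanyl group of compound 1 and instead has methyl in place of hydrogen on an aromatic carbon.

The measured steps all concern the group on the sulfur, so they bear on this change only indirectly. They are a step that the two limits leave unreadable from compound 1 to compound 2, a step that the two limits leave unreadable from compound 1 to compound 3 and a step that the two limits leave unreadable from compound 2 to compound 3. Among the measured compounds shown here, none offers a size to carry over, but no measured compound gives a number in this assay. For the measured compounds named here, the expected change is an at least 1.0-fold lower number from compound 1 to compound 4 (0.02 log units; that floor lies within the scatter), with no step expected beyond the usual scatter. The estimated value for compound 4 is 75000 nM, within an expected range of 30000 nM to 100000 nM.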

Compound 4, half-maximal cytotoxic concentration: > 76000 nM
Compound 4 was reported as a limit; the forecaster's own chance of this, stated with the estimate: 70%; at least 1.0-fold (0.00 log units) between middle value and limit.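

In this assay compound 4 gives > 76000 nM, which is a limit and not a number. Compound 1 also has only a limit, so the step between compound 1 and compound 4 cannot be read. The compounds shown leave open whether methyl in place of hydrogen on an aromatic carbon changes this read-out at all: none of them has an exact value.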